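Iodo for Bromo: a Halogen Swap on the Aromatic Ring

The source may hold more compounds than are shown below. What is called first, only, known or untested is meant among the compounds shown, and "the series" means these compounds.

For the measured compounds named here, compound 2 `NC(=O)c1c(NC(=O)c2ccccc2Br)sc2c1CCN(C(=S)Nc1ccccc1C(F)(F)F)C2` gives 27400 nM in a functional assay on HL-60 cells (Homo sapiens) for antiproliferative activity, with a stated time of 24 h (on this read-out higher numbers stand for weaker inhibition and lower numbers for stronger inhibition), the highest of the two numbers measured so far; compound 1 `NC(=O)c1c(NC(=O)c2ccccc2I)sc2c1CCN(C(=S)Nc1ccccc1Cl)C2` gives 8560 nM, a lower number that lies beyond the scatter. Compound 3 `NC(=O)c1c(NC(=O)c2ccccc2I)sc2c1CCN(C(=S)Nc1ccccc1C(F)(F)F)C2` has not yet been measured. It differs from compound 2 by iodo in place of bromo on an aromatic carbon. Going by the values given here, no pair of measured compounds differs in this one place alone, and compound 1 differs from compound 2 in two places, so the weight of this change cannot be read from the data. Compound 3 is expected to show a step of a 1.4-fold lower number from compound 2 to compound 3 (0.14 log units; within the scatter) that stays within the scatter. The estimate for compound 3 is 20000 nM, with a range from 8000 nM to 50000 nM.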

Compound 3, half-maximal inhibitory concentration: 19700 nM
Estimate against measurement, compound 3: 1.0-fold (0.01 log units) above; the range from low to high includes it.
By their numbers in this assay, from the lowest: compound 1; then compounds 3 and 2 (each within the scatter of the next).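

Iodo in place of bromo on this aromatic carbon, ortho to a large group, comes with a 1.4-fold lower number from compound 2 to compound 3 (0.14 log units; within the scatter), so in this assay these two halogens cannot be told apart here. Trifluoromethyl in place of chloro on an aromatic carbon comes with a 2.3-fold higher number from compound 1 to compound 3 (0.36 log units; beyond the scatter), so of these two single changes only that one goes beyond the scatter. How an amine, a carboxylic acid or a plain hydrogen would read at the halogen's place stays open, and no measurement on hand accounts for either step.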